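The source may report more compounds than this note shows. Statements on the series, on what has been measured and on what is new or still open speak of the compounds shown alone.

Working notes on the series. For the measured compounds named here, in an ADME assay on HEK-293T cells (Homo sapiens) for cytotoxicity, read by MTT assay, with a stated time of 48 h (on this read-out higher numbers stand for lower toxicity in this test and lower numbers for higher toxicity in this test), compound 2 (`CN(C)CCC(=O)O[C@@H]1C[C@@H]2CC[C@@]1(C)C2(C)C`) gives 505000 nM, the higher of the two numbers so far, while compound 1 (`CC1(C)[C@H]2CC[C@]1(C)[C@H](OC(=O)CCCN1CCCCC1)C2`) gives 74800 nM.

The next compound is compound 3 (`CCN(CC)CCCC(=O)O[C@@H]1C[C@@H]2CC[C@@]1(C)C2(C)C`), and the change from compound 2 is (diethylamino)methyl in place of dimethylamino on a saturated chain carbon, two bonds along the chain from a carbonyl carbon. In words, this is (diethylamino)methyl in place of dimethylamino on a saturated chain carbon, two bonds along the chain from a carbonyl carbon.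

Going by the values given here, only one measured step bears on this change: a 6.8-fold higher number from compound 1 to compound 2 (0.83 log units; beyond the scatter), with dimethylamino in place of (piperidin-1-yl)methyl at the same place. The change to compound 3 runs the other way, since dimethylamino leaves and a larger group ending in methyl enters, although this group has no ring. A modest move to a lower number in this assay is therefore expected, probably somewhat smaller than the measured step. With a single step as the basis, this expectation is loose.

The expected step is a 3.9-fold lower number from compound 2 to compound 3 (0.59 log units; beyond the scatter). The estimate for compound 3 is 130000 nM, with an expected range of 50000 nM to 320000 nM.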

Compound 3, half-maximal cytotoxic concentration: 166000 nM
Estimate against measurement, compound 3: 1.3-fold (0.11 log units) below; low and high end bracket the measured number.
By their numbers in this assay, from the lowest: compound 1; then compound 3; then compound 2.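

Compound 3 separates two things that the earlier step from compound 1 to compound 2 changed together, the length of the chain and the form of the amine. With the chain held, diethylamino in place of piperidin-1-yl on a saturated chain carbon, three bonds along the chain from a carbonyl carbon, gives a 2.2-fold higher number from compound 1 to compound 3 (0.35 log units; beyond the scatter) in this assay, so the ring form of the amine is not needed for a number well under that of compound 2, yet the open diethylamino form does not reach compound 2 either. The change to (diethylamino)methyl gives a 3.0-fold lower number from compound 2 to compound 3 (0.48 log units; beyond the scatter), and all three compounds now stand apart beyond the scatter, with the piperidin-1-yl compound lowest and the dimethylamino compound highest.

The chain and the groups on its nitrogen still change together between compound 2 and compound 3, so a dimethylamino group on the longer chain would be needed to divide that step between them. Going by these compounds, how a morpholin-4-yl or pyrrolidin-1-yl group at the end of the longer chain would fall relative to compound 1 and compound 3 remains open, as does the effect of a longer chain still. No measurement available here accounts for these differences.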